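Will a new substituent shift solubility?

The compounds below may be only part of what the source reports. "The series", "measured", "known", "first", "only" and "open" are said of these compounds alone.

In a physicochemical assay for solubility, in phosphate buffer, measured as kinetic solubility, with a stated time of 1 h, at pH 7.4 (on this read-out higher numbers stand for higher solubility and lower numbers for lower solubility), compound 3 `Oc1cccc(-c2nccc([C@]34CCOC[C@H]3C4)n2)c1` gives 141 ug/mL, level with compound 1 `Oc1cccc(-c2nccc([C@@]34CCOC[C@@H]3C4)n2)c1` at 123 ug/mL and compound 2 `CCNC(=O)Nc1ccc(-c2nccc([C@]34CCOC[C@H]3C4)n2)cc1` at 125 ug/mL. Compound 4 `CC(C)(c1cc([C@]23CCOC[C@H]2C3)nc(-c2cccc(O)c2)n1)S(C)(=O)=O` carries a new group on the core of compound 3: 1-methyl-1-(methylsulfonyl)ethyl in place of hydrogen on an aromatic carbon. Among the compounds with values here, only one measured step bears on this, a 1.1-fold higher number from compound 1 to compound 3 (0.06 log units; within the scatter), and it reflects (the fact that compounds 1 and 3 differ only in the configuration as drawn). That step lies within the scatter, but it involves no added group, so it offers only weak guidance here. Within the data shown here, no measured step adds a group at this place, so no shift beyond the scatter in this assay is expected, though with wide uncertainty. The expected step is a 1.4-fold lower number from compound 3 to compound 4 (0.15 log units; within the scatter). For compound 4 the estimate is 100 ug/mL, with an expected range of 35 ug/mL to 190 ug/mL.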

Compound 4, solubility: 135 ug/mL
Compound 4: middle estimate off by 1.4-fold (0.13 log units), on the low side; the range from low to high includes it.
By their numbers in this assay, from the lowest: compounds 1, 2, 4 and 3 (each within the scatter of the next).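

In this assay, this aromatic carbon next to the ring nitrogen takes 1-methyl-1-(methylsulfonyl)ethyl in place of hydrogen with a 1.0-fold lower number from compound 3 to compound 4 (0.02 log units; within the scatter), so this first added group, with its 7 heavy atoms, leaves the read-out within the scatter. This is one group at one place, and no line of data on hand accounts for the result. The compounds shown leave open whether an amine or a carboxylic acid at this place would move the number beyond the scatter, and whether 1-methyl-1-(methylsulfonyl)ethyl would act alike on compound 1.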